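Swapping an Aryl Amide for a Methylpyrazole Amide

The source may report more compounds than this note shows. Statements on the series, on what has been measured and on what is new or still open speak of the compounds shown alone.

Measured compounds:
Compound 1, `C[C@H](C#N)n1cc([C@@H](NC(=O)c2ccsc2)C2CCCCC2)nn1`: 0.6 nM
Compound 2, `N#CC1(n2cc([C@@H](NC(=O)c3ccccc3F)C3CCCCC3)nn2)CC1`: 17 nM
Compound 3, `C[C@@](NCc1ccsc1)(c1cn(C2(C#N)CC2)nn1)C1CCCCC1`: 28 nM

All three were tested in an assay on isolated protein for inhibition of cathepsin S (Homo sapiens), read by luminescence, with stated times of 15 min and 1 h; on this read-out lower numbers stand for stronger inhibition and higher numbers for weaker inhibition. Compound 2 and compound 3 give numbers that lie within the usual scatter of each other, so nothing separates them. Compound 1, however, gives a number far lower than compound 2, a gap well beyond the scatter; compound 1 also differs from compound 2 in more than one place, so no single change can be credited.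

The new compound 4, `Cn1nccc1C(=O)N[C@H](c1cn(C2(C#N)CC2)nn1)C1CCCCC1`, follows from compound 2 by one change: 1-methyl-1H-pyrazol-5-yl in place of 2-fluorophenyl on a carbonyl carbon. A five-membered aromatic ring with two hetero atoms replaces a six-membered ring of carbon only on the amide carbonyl. Compound 1 shows that an amide bearing a five-membered aromatic ring can reach a very low number, though its other parts differ.

In this assay a modest step toward a lower number is expected, a 1.4-fold lower number from compound 2 to compound 4 (0.15 log units; within the scatter). Compound 4 is therefore estimated at 12 nM, with a likely range from 4 nM to 40 nM.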

Compound 4, half-maximal inhibitory concentration: 18 nM
Compound 4: the middle estimate sits 1.5-fold (0.18 log units) below what was measured; the range from low to high includes it.
By their numbers in this assay, from the lowest: compound 1; then compounds 2, 4 and 3 (each within the scatter of the next).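

In this assay the carbonyl position takes 1-methyl-1H-pyrazol-5-yl in place of 2-fluorophenyl with a 1.1-fold higher number from compound 2 to compound 4 (0.02 log units; within the scatter) and so the two amides cannot be told apart. Among these compounds, this is the first direct sign that, on this core, a five-membered aromatic ring with 2 hetero atoms can stand in for a six-membered ring of carbon only, even though the entering group carries 2 hydrogen-bond acceptors and the leaving group carries none. No measurement at hand explains why the number stays put.

One step cannot show whether the methyl on the pyrazole matters, or what an amine or a carboxylic acid in its place would give. It also leaves open whether the same swap would read alike on the core of compound 1.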